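A few compounds are considered here, and "the series" means these few. Any claim that something is new, unique, unknown or untested is made for them only; others in the source may bear on it.

The measured compounds in a functional assay on the whole organism (blood, strain Wistar-Okamoto) with Rattus norvegicus as the target, with a stated time of 5 days; a higher number here means that more compound is needed for the effect, a lower number that less compound is needed:

Compound 1, `Cc1cccc(C)c1/N=C(\NC#N)Nc1cccnc1`: 50 mg/kg
Compound 2, `CC(C)(C)N/C(=N\O)Nc1cccnc1`: > 35 mg/kg, a limit of the assay rather than a number
Compound 3, `CCC(C)(C)N/C(=N\O)Nc1cccnc1`: > 20 mg/kg, a limit of the assay rather than a number

Compound 3 therefore stands only at a limit in this assay; the limit of > 20 mg/kg in this assay, at which 1 of the 3 values shown sits, is the point at which its value sits. One further value is also a limit, namely (the limit of > 35 mg/kg in this assay, at which 1 of the 3 values shown sits), which belongs to compound 2. Among the compounds with values here, the one measured step, a step that the two limits leave unreadable from compound 2 to compound 3, is left unreadable by the two limits, so the set gives no readable step at all. Within the data shown here, compound 1 is the only compound with a number.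

Compound 4, `CCC(CC)N/C(=N\O)Nc1cccnc1`, differs from compound 3 by pentan-3-yl in place of 1,1-dimethylpropyl on an amine nitrogen. Among the measured compounds shown here, none of the measured steps bears on this change: the single step between compound 2 and compound 3 is of another kind and its size cannot be read. With nothing to argue for a change in either direction, no step beyond the scatter is expected in this assay, and the step from compound 3 to compound 4 is estimated at a step that the limit leaves unreadable from compound 3 to compound 4. Compound 4 is thus expected to give about 40 mg/kg, within a range from 15 mg/kg to 100 mg/kg.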

Compound 4, minimum effective dose: 50 mg/kg
Compound 4: middle estimate off by 1.3-fold (0.10 log units), on the low side; measured number inside the range.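

In this assay, the result for compound 4 gives no readable step to compound 3 or to compound 2, as the values of those two compounds are limits rather than numbers. The compounds shown leave open whether pentan-3-yl, tert-butyl and 1,1-dimethylpropyl on an amine nitrogen differ at all in this assay.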